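This account rests on a few compounds, and the source may have more. Where it says the series, first, only, none or still open, it means among the compounds named here.

Measured in a functional assay on PC-3 cells (Homo sapiens) for inhibition, read by sulforhodamine B assay, with a stated time of 48 h, tested at 50 uM; a lower number here means less inhibition of growth, a higher number more inhibition of growth at the concentration tested:
- compound 1 `COc1ccc([C@@H]2C/C(=N/OCc3cn(-c4ccc(O)cc4)nn3)c3cc(CC=C(C)C)c(OC)cc3O2)cc1`: 64%
- compound 2 `COc1ccc([C@@H]2C/C(=N/OCc3cn(-c4ccc(C(=O)c5ccccc5)cc4)nn3)c3cc(CC=C(C)C)c(OC)cc3O2)cc1`: 40%

Of these two compounds, compound 2 has the lower number, and its gap to compound 1 lies beyond the usual scatter. The next compound, compound 3 `COc1ccc([C@@H]2C/C(=N/OCc3cn(-c4ccc(C#N)cc4)nn3)c3cc(CC=C(C)C)c(OC)cc3O2)cc1`, keeps the shared core and changes a single group: cyano in place of benzoyl on an aromatic carbon, para to a large group (cyano in place of benzoyl on an aromatic carbon).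

Within the data shown here, only one measured step bears on this change: a number 24 percentage points lower from compound 1 to compound 2 (beyond the scatter). That modest step came with benzoyl in place of hydroxy on that same aromatic carbon. Compound 3 also lacks the benzoyl group, so a move back towards compound 1 seems the likelier direction. However, no measured compound carries cyano, so the expected rise in this assay is smaller than that earlier step, and this reading remains uncertain. The expected change is a number 12 percentage points higher from compound 2 to compound 3 (beyond the scatter). For compound 3 the estimated value is 52%, with an expected range from 35% to 70%.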

Compound 3, percent growth inhibition at one concentration: 50%
Beside the measured number, compound 3's estimate is 2 percentage points above it; low and high end bracket the measured number.
By their numbers in this assay, from the lowest: compounds 2 and 3 (each within the scatter of the next); then compound 1.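

In this assay, putting cyano in place of benzoyl on this aromatic carbon gives a number 10 percentage points higher from compound 2 to compound 3 (within the scatter) and so does not separate the two compounds, even though a group with an aromatic ring gives way to one with far fewer heavy atoms and no ring. Compound 1 now stands apart from both other compounds: alongside a number 24 percentage points lower from compound 1 to compound 2 (beyond the scatter) there is a number 14 percentage points lower from compound 1 to compound 3 (beyond the scatter) for a group that shares nothing with benzoyl except its place, so among these three compounds the number at this position is highest with hydroxy, and size alone does not order the other two. Nothing available here explains why hydroxy differs from benzoyl and cyano.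

On these data alone, with only hydroxy, benzoyl and cyano at this carbon, it remains open whether a group such as an amine or a carboxylic acid would match compound 1 or sit with compound 2 and compound 3. Every group shown also lies para to a large group, so it remains open whether hydroxy would keep its lead elsewhere on this ring.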